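Triazole series: aryl swap on the ring nitrogen

This account rests on a few compounds, and the source may have more. Where it says the series, first, only, none or still open, it means among the compounds named here.

Three analogues of the shared core have been measured. In a functional assay on PC-12 cells (Rattus norvegicus) for cytotoxicity, read by MTT assay, with stated times of 2 h and 24 h, tested at 5 uM (a lower number here means a weaker effect, a higher number a stronger effect of the compound at the concentration tested), compound 1 `CC(C)(C)c1ccc(-n2nc(-c3ccc(C(F)(F)F)cc3O)nc2-c2ccccc2O)cc1` gives 77.8%. Compound 2 `Oc1cc(C(F)(F)F)ccc1-c1nc(-c2ccccc2O)n(-c2ccc(Cl)cc2)n1` gives 87.3% in this assay, and compound 3 `COc1ccccc1-n1nc(-c2ccc(C(F)(F)F)cc2O)nc1-c1ccccc1O` gives 85.6%. Compound 2 sits with both neighbours inside the usual scatter: a number 9.5 percentage points higher from compound 1 to compound 2 (within the scatter) and a number 1.7 percentage points lower from compound 2 to compound 3 (within the scatter), so no ordering among the three can be claimed.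

Compound 4 `Oc1cc(C(F)(F)F)ccc1-c1nc(-c2ccccc2O)n(-c2cccc(F)c2)n1` is not yet measured. It differs from compound 2 as follows: 3-fluorophenyl in place of 4-chlorophenyl on an aromatic nitrogen. For the measured compounds named here, the steps that bear on this change are the swap of the group on the ring-nitrogen aryl, a number 9.5 percentage points higher from compound 1 to compound 2 (within the scatter), and the swap of that whole aryl, a number 1.7 percentage points lower from compound 2 to compound 3 (within the scatter); both stayed within the scatter, as did a number 7.8 percentage points higher from compound 1 to compound 3 (within the scatter). The same is therefore expected for the step to compound 4 in this assay: a change not beyond the scatter, in no preferred direction, a number 3.3 percentage points lower from compound 2 to compound 4 (within the scatter). On this basis compound 4 is estimated at 84%, with a range from 72% to 95%.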

Compound 4, a percentage reported as activity, at one concentration (the size of the read-out at that concentration, not a potency): 87.7%
Estimate against measurement, compound 4: 3.7 percentage points below; the range from low to high includes it.
By their numbers in this assay, from the lowest: compounds 1, 3, 2 and 4 (each within the scatter of the next).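

In this assay, 3-fluorophenyl in place of 4-chlorophenyl on the aromatic nitrogen gives a number 0.4 percentage points higher from compound 2 to compound 4 (within the scatter) on the scale of this read-out, so this exchange of both the halogen and its place on the aryl leaves no readable change. The other two comparisons agree, with a number 2.1 percentage points higher from compound 3 to compound 4 (within the scatter) and a number 9.9 percentage points higher from compound 1 to compound 4 (within the scatter) for the new group, and the four aryl groups at this position therefore cannot be told apart at the single concentration tested. No available data bear on why this position shows so little response.

Open, on these data alone, is whether the read-out stays this flat with a carboxylic acid or an amine on the aryl, or with a longer alkyl chain in place of the aryl. The compounds shown also leave open what a change at the 2-hydroxyphenyl group would do.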